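Trimethoxyphenyl for methylphenyl on the enone chain

This account rests on a few compounds, and the source may have more. Where it says the series, first, only, none or still open, it means among the compounds named here.

Three enone-bearing compounds on a shared core type have numbers. Compound 1 `COc1cc(C(=O)/C=C/c2cc(-c3cc(OC)c(OC)c(OC)c3)n3nc(-c4ccccc4)cc3n2)cc(OC)c1OC` gives 24300 nM in a functional assay on MDA-MB-231 cells (Homo sapiens) for antiproliferative activity, read by MTT assay, with a stated time of 24 h; on this read-out lower numbers stand for stronger inhibition and higher numbers for weaker inhibition. Compound 2 `COc1ccc(-c2cc(C(=O)/C=C/c3ccc(C)cc3)nc3cc(-c4ccccc4)nn23)cc1OC` gives 22600 nM in this assay. Compound 3 `COc1cc(-c2cc(/C=C/C(=O)c3ccc(C)cc3)nc3cc(-c4ccccc4)nn23)cc(OC)c1OC` gives 23900 nM in this assay. All three numbers sit within the scatter of one another, so no order among them is read.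

Within the data shown here, the one counted step is 3,4,5-trimethoxyphenyl in place of 4-methylphenyl on a carbonyl carbon. It made a 1.0-fold higher number from compound 3 to compound 1 (0.01 log units; within the scatter). The cores of compound 2 and compound 3 differ, but that difference is not broken down here.

Compound 4 `COc1ccc(-c2cc(C(=O)/C=C/c3cc(OC)c(OC)c(OC)c3)nc3cc(-c4ccccc4)nn23)cc1OC` is not yet measured. It arises from compound 2 by 3,4,5-trimethoxyphenyl in place of 4-methylphenyl on a double-bonded chain carbon bound to a double-bonded chain carbon. The place lines are not the same word for word: in the measured pair the group sits on a carbonyl carbon, whereas here it sits on a double-bonded chain carbon bound to a double-bonded chain carbon; this is the same kind of change, not the same change.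

Because a 1.0-fold higher number from compound 3 to compound 1 (0.01 log units; within the scatter) lay within the scatter, the step from compound 2 to compound 4 is expected to be a 1.0-fold lower number from compound 2 to compound 4 (0.01 log units; within the scatter), resting on that single precedent and on the unmeasured difference between the cores. Compound 4 is therefore estimated at 22000 nM, expected between 9000 nM and 55000 nM.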

Compound 4, half-maximal inhibitory concentration: 16700 nM
Compound 4: middle estimate off by 1.3-fold (0.12 log units), on the high side, within the range that was stated.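

In this assay, 3,4,5-trimethoxyphenyl in place of 4-methylphenyl on a double-bonded chain carbon bound to a double-bonded chain carbon gives a 1.4-fold lower number from compound 2 to compound 4 (0.13 log units; within the scatter). Set beside the earlier step, where the group sits on a carbonyl carbon, the two cores give no readable difference: the same change on two cores in this assay, a 1.0-fold higher number (0.01 log units; within the scatter) from compound 3 to compound 1 and a 1.4-fold lower number (0.13 log units; within the scatter) from compound 2 to compound 4, 1.4-fold (0.14 log units) apart, within the scatter of two such steps So the change leaves the number within the scatter on both cores, but two small steps show neither a real gain from the change nor how it would behave on a further core, and they cannot separate the core from the place of the group.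

The compounds shown leave open whether an amine or a carboxylic acid on the aromatic ring of the enone chain would move the number beyond the scatter. They also leave open whether a saturated chain in place of the enone would do so.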